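Chloro to hydrogen on the benzyl ring of compound 2

The source may hold more compounds than are shown below. What is called first, only, known or untested is meant among the compounds shown, and "the series" means these compounds.

Measured so far in a functional assay (spleen, spleen) for activation, with Mus musculus as the target; a lower number here means that less compound is needed, a higher number that more compound is needed for the effect:
compound 1 `CCCCc1nc(N)c2nc(O)n(Cc3ccccc3)c2n1` gives 0.03 uM
compound 2 `Nc1ncnc2c1nc(O)n2Cc1ccc(Cl)cc1` gives 10 uM
compound 3 `CCCCCOc1nc(N)c2nc(O)n(Cc3ccccc3)c2n1` gives 0.01 uM

Compound 2 stands at the highest number of the three, so it needs the most compound for the effect. Going by the values given here, the only single-point step among the measured compounds is a 3.0-fold lower number from compound 1 to compound 3 (0.48 log units; beyond the scatter), which concerns the group on the core rather than the benzyl ring, so no measured step directly informs the change to compound 4 `Nc1ncnc2c1nc(O)n2Cc1ccccc1`. The change is hydrogen in place of chloro on an aromatic carbon. Among the compounds with values here, with no measured pair showing the effect of removing a chloro from the benzyl ring, no step beyond the scatter is expected in this assay; the expected step is no change at the digits printed from compound 2 to compound 4 (within the scatter). On these data alone, compound 4 is therefore estimated at 10 uM, with a range of 3 uM to 30 uM; the gap between compound 1 and compound 2 suggests that the core substituent, not the chloro, carries most of the difference seen so far, but this remains untested.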

Compound 4, minimum effective concentration: 10 uM
Compound 4: middle estimate and measured number agree at the digits printed; measured number inside the range.
By their numbers in this assay, from the lowest: compound 3; then compound 1; then compounds 2 and 4 (each within the scatter of the next).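

In this assay, the step at this position on the benzyl ring, para to a large group, is no change at the digits printed from compound 2 to compound 4 (within the scatter), so replacing chloro with hydrogen gives no detectable shift on this hydrogen-bearing version of the shared core. Compound 4 also gives the group on the core a direct hydrogen reference, with a 1000-fold higher number from compound 3 to compound 4 (3.00 log units; beyond the scatter) and a 330-fold higher number from compound 1 to compound 4 (2.52 log units; beyond the scatter), placing the large steps in this set at that aromatic carbon rather than at the chloro. No measured evidence bears on the reason for any of these steps.

On these data alone, whether chloro is equally without effect on the benzyl ring when butyl or pentyloxy sits on the core remains open. Also open, as far as these compounds go, is how an amine or a chain longer than pentyloxy on the core, or a carboxylic acid on the benzyl ring, would compare.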